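Lactone series: epimer at the ring stereocentre

The source may hold more compounds than are shown below. What is called first, only, known or untested is meant among the compounds shown, and "the series" means these compounds.

Measured so far:
- compound 1, `O=C1C=CC[C@H](/C=C/c2ccc([N+](=O)[O-])cc2)O1`: 15400 nM
- compound 2, `O=C1C=CC[C@@H]([C@H]2C[C@@H]2c2ccccc2)O1`: 15200 nM

Two compounds have been run in a functional assay on A549 cells (Homo sapiens) for antiproliferative activity, read by luminescence and CellTiter-Glo, with a stated time of 48 h; on this read-out lower numbers stand for stronger inhibition and higher numbers for weaker inhibition. Compound 1 gives 15400 nM in this assay. Compound 2 gives 15200 nM in this assay. Within the data shown here, the two numbers lie within the scatter of each other, so compound 2 and compound 1 cannot be told apart on these data, and no ranking within the pair is warranted. Among the measured compounds shown here, no step between measured compounds that differ in one place has been recorded.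

The next compound, compound 3, `O=C1C=CC[C@H]([C@H]2C[C@@H]2c2ccccc2)O1`, is not yet measured. Relative to compound 2 the change is the two compounds have the same atoms and bonds and differ only in configuration as drawn: 1 of 3 stereo elements differ; a stereocentre at a saturated ring carbon is drawn S in compound 2 and R in compound 3. For the measured compounds named here, there is no measured pair that separates the two configurations at this centre, so the direction of the step cannot be read from the data. A step of any size beyond the scatter, in either direction, is possible; the default expectation, lacking evidence, is a step of a 1.0-fold lower number from compound 2 to compound 3 (0.01 log units; within the scatter) in this assay, with a wide range. Compound 3 is therefore estimated at 15000 nM in this assay, between 4000 nM and 60000 nM.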

Compound 3, half-maximal inhibitory concentration: 11600 nM
For compound 3 the middle estimate is 1.3-fold (0.11 log units) above the measured one; low and high end bracket the measured number.
By their numbers in this assay, from the lowest: compounds 3, 2 and 1 (each within the scatter of the next).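

Among these compounds, the pair isolates a single stereocentre at a saturated ring carbon, drawn S in compound 2 and R in compound 3, and it is the first measured pair to separate these two configurations: the fact that compounds 2 and 3 differ only in the configuration as drawn. In this assay the pair gives a 1.3-fold lower number from compound 2 to compound 3 (0.12 log units; within the scatter), so changing this centre alone produces no difference that can be distinguished from the usual scatter of repeated measurements. Neither configuration can be preferred on these numbers, and this reading holds only for this pair, with the other two stereo elements drawn as they are in compound 2 and compound 3.

Among the compounds shown here, the contribution of those other two stereo elements remains open, since they are the same in both compounds and no measured pair separates their configurations. Also open, from the compounds shown here alone, is whether an amine or a carboxylic acid on the shared core would change the numbers in this assay, and whether the S and R configurations at this centre would still be indistinguishable with such a group present.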